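Acylhydrazones on a furan–benzoic acid core: step to compound 3

The source may hold more compounds than are shown below. What is called first, only, known or untested is meant among the compounds shown, and "the series" means these compounds.

Measured compounds:
compound 1 `COc1cc(C(=O)N/N=C/c2cc(-c3cccc(C(=O)O)c3)co2)cc(OC)c1OC` — 48000 nM
compound 2 `O=C(O)c1cccc(-c2ccc(/C=N/NC(=O)c3ccc4[nH]ncc4c3)o2)c1` — 45000 nM

In a functional assay on Raji cells (Homo sapiens) for antiproliferative activity, read by trypan blue exclusion, with a stated time of 24 h (on this read-out higher numbers stand for weaker inhibition and lower numbers for stronger inhibition), compound 1 gives 48000 nM and compound 2 gives 45000 nM. The two numbers lie within the scatter of each other, so compound 2 cannot be set apart from compound 1 on this assay; both sit at weak inhibition.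

Compound 3 `N#CCC(=O)N/N=C/c1ccc(-c2cccc(C(=O)O)c2)o1` keeps the shared core of compound 2 and differs by cyanomethyl in place of 1H-indazol-5-yl on a carbonyl carbon. Going by the values given here, no pair of measured compounds shows this kind of change, so the size of the step has no precedent here. Given that compound 2 in this assay gives 45000 nM, and that compound 1 with a different aryl piece at the same carbonyl carbon gives 48000 nM, the expected step from compound 2 to compound 3 is a 1.7-fold higher number from compound 2 to compound 3 (0.22 log units; within the scatter), a modest move toward weaker inhibition. Compound 3 is thus estimated at 75000 nM, within 25000 nM to 250000 nM.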

Compound 3, half-maximal inhibitory concentration: 64000 nM
Compound 3: middle estimate off by 1.2-fold (0.07 log units), on the high side; low and high end bracket the measured number.
By their numbers in this assay, from the lowest: compounds 2, 1 and 3 (each within the scatter of the next).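

In this assay, going by these compounds alone, cyanomethyl in place of 1H-indazol-5-yl on a carbonyl carbon gives a 1.4-fold higher number from compound 2 to compound 3 (0.15 log units; within the scatter), the first one-place step. At this position, a group with no ring and fewer heavy atoms therefore cannot be told apart from the two-ring 1H-indazol-5-yl, even though the hydrogen-bond donor of that group is lost. No measured evidence on this result is at hand, so the flat reading stays unexplained.

From the compounds shown here alone, whether any group on this carbonyl carbon can move the number beyond the scatter remains open, and a longer chain ending in an amine would be one test of that. The carboxylic acid on the shared core is also constant across all the compounds shown, so the effect of a methyl ester in its place is unknown.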